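Vero cytotoxicity across a shared benzimidazole-free core series

The compounds below may be only part of what the source reports. "The series", "measured", "known", "first", "only" and "open" are said of these compounds alone.

Measured so far:
Compound 1 `O=C(CN1CCCCC1)Nc1ccc(-c2nc3cc(C(F)(F)F)ccc3[nH]2)cc1` gives 31000 nM in an ADME assay on Vero cells (Chlorocebus sabaeus) for cytotoxicity; a lower number here means that less compound is tolerated, a higher number that more compound is tolerated.
Compound 2 `COc1ccc(-c2nc3cc(C(F)(F)F)ccc3[nH]2)c(N)c1` gives 50000 nM in this assay.
Compound 3 `O=C(CCl)Nc1ccc(-c2nc3cc(C(F)(F)F)ccc3[nH]2)cc1` gives 35000 nM in this assay.

All three numbers lie within the scatter of one another, so compound 3 is not separable from compound 1 or compound 2 in this assay. Within the data shown here, the only measured step, a 1.1-fold higher number from compound 1 to compound 3 (0.05 log units; within the scatter), alters the chain carbon and leaves the rest untouched.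

Compound 4 `O=[N+]([O-])c1ccc(-c2nc3cc(C(F)(F)F)ccc3[nH]2)cc1` differs from compound 3 by nitro in place of ((chloromethyl)carbonyl)amino on an aromatic carbon. Among the measured compounds shown here, no measured step touches this position, so the expectation rests on the flat picture so far: a step of no change at the digits printed from compound 3 to compound 4 (within the scatter) is expected, within the scatter. Compound 4 is therefore estimated at 35000 nM, with a range of 15000 nM to 80000 nM.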

Compound 4, half-maximal cytotoxic concentration: 45000 nM
Beside the measured number, compound 4's estimate is 1.3-fold (0.11 log units) below it; the measured number falls inside the stated range.
By their numbers in this assay, from the lowest: compounds 1, 3, 4 and 2 (each within the scatter of the next).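

On the aromatic carbon para to a large group, nitro in place of ((chloromethyl)carbonyl)amino gives a 1.3-fold higher number from compound 3 to compound 4 (0.11 log units; within the scatter) in this assay. The earlier step changed only the end of the chain, whereas this one removes the whole ((chloromethyl)carbonyl)amino group, including the amide hydrogen, with no separable shift in the read-out. No supporting data bear on why this position reads flat. Still open, going by these compounds, is whether a carboxylic acid or a nitrile on this aromatic carbon would stay within the scatter in this assay.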